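A few compounds are considered here, and "the series" means these few. Any claim that something is new, unique, unknown or untested is made for them only; others in the source may bear on it.

Measured in an ADME assay on HepG2 cells (Homo sapiens) for cytotoxicity, read by MTT assay, with a stated time of 48 h; a higher number here means a weaker inhibitor, a lower number a stronger inhibitor:
- Compound 1 `CC(C)CN1C(=O)/C(=C/c2ccc(N(C)C)cc2)S/C1=N\c1ccccc1`: > 100000 nM
- Compound 2 `COc1ccc(/C=C2\S/C(=N\c3ccccc3)N(CC(C)C)C2=O)cc1OC`: > 100000 nM
- Compound 3 `Cc1ccc(/C=C2\S/C(=N\c3ccccc3)N(CC(C)C)C2=O)cc1`: "not determined" (no result reported)

The values for compound 1 and compound 2 are limits of the assay, not exact numbers. Compound 3 has no result to place it on the scale, as its entry reads "not determined" (no result reported). For the measured compounds named here, the only guide in this assay is the limit of > 100000 nM in this assay, at which 2 of the 3 values shown sit.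

Compound 4 `CC(C)CN1C(=O)/C(=C/c2cccc(Cl)c2)S/C1=N\c1ccccc1` has not yet been measured. The structural step 3-chlorophenyl in place of 4-methylphenyl on a double-bonded chain carbon bound to a double-bonded ring carbon places 3-chlorophenyl in place of 4-methylphenyl on a double-bonded chain carbon bound to a double-bonded ring carbon. Going by the values given here, no measured step shows what such a swap does here, so only a small change is expected in this assay, perhaps a slight move towards stronger inhibition. A result reported only as a limit is also quite likely. Compound 4 is estimated at 80000 nM, with an expected range from 30000 nM to 100000 nM.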

Compound 4, half-maximal inhibitory concentration: 88100 nM
Estimate against measurement, compound 4: 1.1-fold (0.04 log units) below; the measured number falls inside the stated range.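

In this assay compound 4 gives 88100 nM, the only exact number among the compounds shown, and so the first reading at this position that is not a limit. Putting 3-chlorophenyl in place of 4-(dimethylamino)phenyl on a double-bonded chain carbon bound to a double-bonded ring carbon gives an at least 1.1-fold lower number from compound 1 to compound 4 (0.05 log units; that floor lies within the scatter), so this change cannot be said to have moved the number in a real way. The exact value of compound 4 therefore adds little to what was already seen, and its reading stays close to the earlier ceiling: the limit of > 100000 nM in this assay, at which 2 of the 4 values shown sit.

Compound 3 has no result, so its step to compound 4 cannot be read. Also open, as far as these compounds go, is what a carboxylic acid or a nitrile on the phenyl ring at this position would do to the number.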